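The source may hold more compounds than are shown below. What is called first, only, known or untested is meant among the compounds shown, and "the series" means these compounds.

Among the measured compounds shown here, compound 1 `COc1ccc(-c2cnc3nc(N)nc(N4CCN(c5cc(Cl)cc(Cl)c5)CC4)c3n2)cc1OC` is the only compound here with a numbered result: in a functional assay on cells (T-cell, Homo sapiens) for inhibition (a lower number here means a stronger inhibitor, a higher number a weaker inhibitor), compound 1 gives 3400 nM. Compound 2 `CC(C)Oc1nc(N)nc2ncc(-c3ccc(C(F)(F)F)cc3)nc12` reaches only a limit of the assay, and in this assay compound 2 gives > 10000 nM. For compound 2 this is the limit of > 10000 nM in this assay, at which 1 of the 2 values shown sits. Compound 3 `COc1ccc(-c2cnc3nc(N)nc(N4CCN(Cc5c(Cl)cccc5Cl)CC4)c3n2)cc1OC` differs from compound 1 in that (2,6-dichlorobenzyl in place of 3,5-dichlorophenyl on an amine nitrogen in a ring). For the measured compounds named here, no step between measured compounds is at hand, so the direction is open; a change beyond the scatter is possible either way. Compound 3 is expected to give about 5000 nM in this assay, between 1500 nM and 20000 nM. The expected step of a 1.5-fold higher number from compound 1 to compound 3 (0.17 log units; within the scatter) is modest.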

Compound 3, half-maximal inhibitory concentration: 7600 nM
Compound 3: middle estimate off by 1.5-fold (0.18 log units), on the low side; measured number inside the range.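

On the amine nitrogen in a ring, this position responds to the group it carries: in this assay, 2,6-dichlorobenzyl in place of 3,5-dichlorophenyl brings a 2.2-fold higher number from compound 1 to compound 3 (0.35 log units; beyond the scatter). Even so, compound 3 still gives a numbered result rather than a limit of the assay. Nothing at hand accounts for this step. The step joins the extra carbon and the changed chlorine pattern, and the compounds shown do not separate the two. From the compounds shown here alone, how an unsubstituted benzyl or a carboxylic acid on that ring would fare also remains open.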